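The source may hold more compounds than are shown below. What is called first, only, known or untested is meant among the compounds shown, and "the series" means these compounds.

Measured so far in a functional assay on isolated protein for inhibition of Glucose-dependent insulinotropic receptor (Homo sapiens), read by HTRF and cAMP accumulation; a higher number here means that more compound is needed for the effect, a lower number that less compound is needed:

compound 1 `Cc1nc(S(C)(=O)=O)ccc1Oc1ncnc(OC2CCN(C(=O)OC(C)C)CC2)c1F` — 21 nM
compound 2 `Cc1nc(S(C)(=O)=O)ccc1Oc1ncnc(OC2CCN(C(=O)OC3CCC3)CC2)c1F` — 13.6 nM
compound 3 `Cc1nc(S(C)(=O)=O)ccc1Oc1ncnc(OC2CCN(C(=O)OC(C)(C)C(F)(F)F)CC2)c1F` — 6.53 nM

Compound 3 holds the lowest number of the three in this assay. Its lead over compound 2 is a 2.1-fold lower number from compound 2 to compound 3 (0.32 log units; beyond the scatter) and its lead over compound 1 is a 3.2-fold lower number from compound 1 to compound 3 (0.51 log units; beyond the scatter); both lie beyond the scatter, whereas the step of a 1.5-fold lower number from compound 1 to compound 2 (0.19 log units; within the scatter) does not. The series therefore shows one reliable move, the gain on going from compound 1 to compound 3.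

Compound 4 `Cc1nc(S(C)(=O)=O)ccc1Oc1ncnc(OC2CCN(C(=O)O[C@@H](C)CF)CC2)c1F` differs from compound 3 in a single place: 1-(fluoromethyl)ethyl in place of 1-methyl-1-(trifluoromethyl)ethyl on an oxygen next to a carbonyl group. Within the data shown here, the only measured step that bears directly on this position is a 3.2-fold lower number from compound 1 to compound 3 (0.51 log units; beyond the scatter), where trifluoromethyl entered on the carbon bound to the carbamate oxygen. Among the measured compounds shown here, compound 4 gives that trifluoromethyl up and takes a smaller fluorinated group in its place, so structurally it sits between compound 1 and compound 3; no measured pair tells how much of the gain the remaining fluorine retains.

The expectation is therefore a modest rise in the number from compound 3, estimated as a 1.8-fold higher number from compound 3 to compound 4 (0.26 log units; within the scatter), landing between compound 3 and compound 1 rather than beyond either. For compound 4 the estimated value in this assay is 12 nM, with a range of 5 nM to 30 nM.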

Compound 4, half-maximal effective concentration: 186 nM
Compound 4: the middle estimate sits 16-fold (1.19 log units) below what was measured; the measured number lies above the stated range.
By their numbers in this assay, from the lowest: compound 3; then compounds 2 and 1 (each within the scatter of the next); then compound 4.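

In this assay, the place on an oxygen next to a carbonyl group turns out to be far more sensitive than the earlier modest steps there showed, with a 28-fold higher number from compound 3 to compound 4 (1.45 log units; beyond the scatter) as the largest change in the series. The drop is not confined to the comparison with the 1-methyl-1-(trifluoromethyl)ethyl group: cyclobutyl gives way to 1-(fluoromethyl)ethyl in a 14-fold higher number from compound 2 to compound 4 (1.14 log units; beyond the scatter), and a single fluoro in place of hydrogen gives an 8.9-fold higher number from compound 1 to compound 4 (0.95 log units; beyond the scatter), a move opposite in direction to a 3.2-fold lower number from compound 1 to compound 3 (0.51 log units; beyond the scatter), so fluorination at this place has no single direction across compound 1, compound 3 and compound 4. The data at hand offer no explanation for this reversal.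

The compounds shown leave open whether the rise follows from the fluoro itself or from the defined stereocentre, which only compound 4 carries, since its mirror-image form does not appear among them. A 1-(trifluoromethyl)ethyl or a tert-butyl group on the same oxygen would help separate the contribution of the trifluoromethyl group from that of the fully substituted carbon.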